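Growing the Ester Group from Methoxy to Phenyl

The compounds below may be only part of what the source reports. "The series", "measured", "known", "first", "only" and "open" are said of these compounds alone.

Compound 3 `COC(=O)C1=C(C)NC(C)=C(C(=O)OCc2ccc(OC)cc2)C1c1cccc([N+](=O)[O-])c1` gives 79 nM in a functional assay on HEK293 cells for antagonist activity at Voltage-dependent L-type calcium channel subunit alpha-1D (Rattus norvegicus), read by FLIPR (on this read-out lower numbers stand for stronger inhibition and higher numbers for weaker inhibition), the second highest of the three numbers shown; compound 1 `COC(=O)C1=C(C)NC(C)=C(C(=O)OCCCl)C1c1cccc([N+](=O)[O-])c1` gives 22 nM and compound 2 `COC(=O)C1=C(C)NC(C)=C(C(=O)OCC(C)[N+](=O)[O-])C1c1cccc([N+](=O)[O-])c1` gives 111 nM. Compound 4 `COC(=O)C1=C(C)NC(C)=C(C(=O)OCc2ccc(-c3ccccc3)cc2)C1c1cccc([N+](=O)[O-])c1` differs from compound 3 by phenyl in place of methoxy on an aromatic carbon, so that 4-methoxyphenyl becomes 4-phenylphenyl. Among the compounds with values here, no measured step exchanges one group for another on that aromatic ring; the nearest comparisons enlarge the ester substituent itself: a 3.6-fold higher number from compound 1 to compound 3 (0.56 log units; beyond the scatter) and a 5.0-fold higher number from compound 1 to compound 2 (0.70 log units; beyond the scatter), while a 1.4-fold lower number from compound 2 to compound 3 (0.15 log units; within the scatter). Enlarging the ester group has so far given modestly higher numbers or no change beyond the scatter. Compound 4 is therefore expected to show a 1.6-fold higher number from compound 3 to compound 4 (0.22 log units; within the scatter), a small rise at most. Compound 4 is estimated at 130 nM, with a range from 40 nM to 450 nM.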

Compound 4, half-maximal inhibitory concentration: 74 nM
Beside the measured number, compound 4's estimate is 1.8-fold (0.24 log units) above it; the range from low to high includes it.
By their numbers in this assay, from the lowest: compound 1; then compounds 4, 3 and 2 (each within the scatter of the next).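

In this assay, phenyl in place of methoxy on an aromatic carbon, para to a large group, adds a six-membered aromatic ring with no change beyond the scatter (a 1.1-fold lower number from compound 3 to compound 4 (0.03 log units; within the scatter)). The larger 4-phenylphenyl group also stays within the scatter of 1-nitroethyl (a 1.5-fold lower number from compound 2 to compound 4 (0.18 log units; within the scatter)), yet it remains beyond the scatter against chloromethyl (a 3.4-fold higher number from compound 1 to compound 4 (0.53 log units; beyond the scatter)). Nothing measured here explains why the number holds steady at this position. Going by these compounds, whether an amine or a carboxylic acid on this aromatic carbon would shift the number remains open.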